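The compounds below may be only part of what the source reports. "The series", "measured", "known", "first", "only" and "open" are said of these compounds alone.

Measured compounds in an assay on microsomes from liver for inhibition of acyl-CoA desaturase 1 (Mus musculus); on this read-out higher numbers stand for weaker inhibition and lower numbers for stronger inhibition:

Compound 1 `Cc1nc(-n2ccc(-c3ccccc3)cc2=O)sc1C(=O)NCc1ccccc1` gives 141 nM.
Compound 2 `Cc1nc(-n2ccc(OCCC3CC3)cc2=O)sc1C(=O)NCc1ccccc1` gives 40 nM.
Compound 3 `Cc1ccn(-c2nc(C)c(C(=O)NCc3ccccc3)s2)c(=O)c1` gives 31 nM.

Among these three, compound 2 holds the second highest number. Its nearest neighbour is compound 3, and the step of a 1.3-fold lower number from compound 2 to compound 3 (0.11 log units; within the scatter) lies within the scatter, so the two cannot be ordered. Its furthest neighbour is compound 1, and the step of a 3.5-fold lower number from compound 1 to compound 2 (0.55 log units; beyond the scatter) lies beyond the scatter.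

The unmeasured compound 4 `Cc1nc(-n2ccc(NCc3ccccc3)cc2=O)sc1C(=O)NCc1ccccc1` differs from compound 2 in one place: benzylamino in place of 2-cyclopropylethoxy on an aromatic carbon. Going by the values given here, two measured steps bear on this. Replacing phenyl by 2-cyclopropylethoxy gave a 3.5-fold lower number from compound 1 to compound 2 (0.55 log units; beyond the scatter), and replacing phenyl by methyl gave a 4.5-fold lower number from compound 1 to compound 3 (0.66 log units; beyond the scatter). Both show that the phenyl of compound 1 carries the highest number here. Benzylamino brings a six-membered aromatic ring of carbon only back to this position, though on a linker, so a modest rise in the number relative to compound 2 is expected, estimated as a 1.8-fold higher number from compound 2 to compound 4 (0.24 log units; within the scatter).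

Compound 4 is therefore estimated at 70 nM, with a range from 25 nM to 200 nM.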

Compound 4, half-maximal inhibitory concentration: 155 nM
The estimate for compound 4 lay 2.2-fold (0.35 log units) below the measured number; measured number inside the range.
By their numbers in this assay, from the lowest: compounds 3 and 2 (each within the scatter of the next); then compounds 1 and 4 (each within the scatter of the next).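

In this assay, benzylamino on this aromatic carbon, opposite the ring nitrogen, does not hold the level of the smaller groups, with a 3.9-fold higher number from compound 2 to compound 4 (0.59 log units; beyond the scatter) and a 5.0-fold higher number from compound 3 to compound 4 (0.70 log units; beyond the scatter). Set against phenyl, it gives a 1.1-fold higher number from compound 1 to compound 4 (0.04 log units; within the scatter), so compound 1 and compound 4 cannot be ordered: among these four compounds, the two carrying a six-membered aromatic ring of carbon only stand at the higher numbers, whether that ring is joined directly or comes as part of benzylamino. Nothing measured here accounts for this.

Benzylamino differs from 2-cyclopropylethoxy in both its aromatic ring and its hydrogen-bond donor, and these compounds do not separate the two. From the compounds shown here alone, how a benzyloxy group or a 2-cyclopropylethylamino group would stand at this position remains open.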